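Pyridin-3-yl amide in a cyclopentyloxy-methoxybenzamide series

A few compounds are considered here, and "the series" means these few. Any claim that something is new, unique, unknown or untested is made for them only; others in the source may bear on it.

Compound 1 `COc1ccc(C(=O)Nc2c(F)cccc2Cl)cc1OC1CCCC1` gives 240 nM in an assay on isolated protein for inhibition of phosphodiesterase 4A (Sus scrofa); a higher number here means a weaker inhibitor, a lower number a stronger inhibitor; compound 2 `COc1ccc(C(=O)Nc2c(C)cccc2Cl)cc1OC1CCCC1` gives 100 nM; compound 3 `COc1ccc(C(=O)Nc2ccccc2O)cc1OC1CCCC1` gives 1300 nM.

Compound 3 stands highest of the three: a 5.4-fold higher number from compound 1 to compound 3 (0.73 log units; beyond the scatter) and a 13-fold higher number from compound 2 to compound 3 (1.11 log units; beyond the scatter), both beyond the scatter. Compound 4 `COc1ccc(C(=O)Nc2cccnc2)cc1OC1CCCC1` differs from compound 3 by pyridin-3-yl in place of 2-hydroxyphenyl on an amide-type nitrogen. Within the data shown here, no measured step swaps the whole ring for one with a ring nitrogen and no donor, so the bearing steps are only the two that lead into compound 3, both of which move the number up as the ortho groups are thinned. A further change of that kind is therefore expected to give a modest rise, estimated as a 2.3-fold higher number from compound 3 to compound 4 (0.36 log units; beyond the scatter), though a step within the scatter cannot be excluded. Compound 4 is expected at 3000 nM, between 800 nM and 12000 nM.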

Compound 4, half-maximal inhibitory concentration: 550 nM
For compound 4 the middle estimate is 5.5-fold (0.74 log units) above the measured one; measured number below the stated range.
By their numbers in this assay, from the lowest: compound 2; then compound 1; then compound 4; then compound 3.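

On the amide-type nitrogen in this assay, pyridin-3-yl in place of 2-hydroxyphenyl gives a 2.4-fold lower number from compound 3 to compound 4 (0.37 log units; beyond the scatter) here, so the hydrogen-bond donor of 2-hydroxyphenyl is not required at this position. Pyridin-3-yl still trails both substituted phenyl rings, with a 5.5-fold higher number from compound 2 to compound 4 (0.74 log units; beyond the scatter) and a 2.3-fold higher number from compound 1 to compound 4 (0.36 log units; beyond the scatter) on the same nitrogen. No measurement at hand explains these steps.

The compounds shown leave open whether the ring nitrogen or the loss of hydroxyl drives the improvement, which unsubstituted phenyl would separate. They also leave open whether pyridin-4-yl would behave alike.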